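The source may hold more compounds than are shown below. What is called first, only, known or untested is meant among the compounds shown, and "the series" means these compounds.

In a functional assay on HCT-116 cells (Homo sapiens) for cytotoxicity, read by MTT assay (a lower number here means a stronger inhibitor, a higher number a weaker inhibitor), compound 1 (`Cc1cc(O)c(C(=O)/C=C/c2cccs2)c(=O)o1`) gives > 100000 nM as a limit of the assay, not a number. Compound 2 (`Cc1cc(O)c(C(=O)/C=C/c2ccco2)c(=O)o1`) gives > 100000 nM in this assay and that too is a limit. The two compounds stand together: the limit of > 100000 nM in this assay, at which 2 of the 2 values shown sit. Compound 3 (`Cc1cc(O)c(C(=O)/C=C/c2ccc[nH]2)c(=O)o1`) brings one change from compound 2: 1H-pyrrol-2-yl in place of furan-2-yl on a double-bonded chain carbon bound to a double-bonded chain carbon. Among the compounds with values here, the only measured step bearing on this change, also a swap between five-membered aromatic rings, is a step that the two limits leave unreadable from compound 1 to compound 2 and it offers no size to carry over. No direction is favoured, and the expected step is a number no higher from compound 2 to compound 3 (the limit leaves the size open) with little weight on it. Compound 3 is estimated at 100000 nM in an expected range from 40000 nM to 200000 nM and may well report only a limit.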

Compound 3, half-maximal inhibitory concentration: > 100000 nM
Compound 3 ended at the assay's limit (the forecaster's own chance of this, stated with the estimate: 75%); the middle value lies on the limit itself.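

The steps among compound 1, compound 2 and compound 3 cannot be read, since each result is a limit and not a number: the limit of > 100000 nM in this assay, at which 3 of the 3 values shown sit.

These compounds leave open whether thiophen-2-yl, furan-2-yl and 1H-pyrrol-2-yl differ at all in this assay.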